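Fluoro to chloro on compound 3: expected cytotoxicity

The source may report more compounds than this note shows. Statements on the series, on what has been measured and on what is new or still open speak of the compounds shown alone.

The series shares one core, read in a functional assay on HL-60 cells (Homo sapiens) for cytotoxicity, read by CCK-8 assay, with a stated time of 72 h; a higher number here means a weaker inhibitor, a lower number a stronger inhibitor. Compound 1 `C=CCn1c(=O)/c(=C\c2cc(F)ccc2C)[nH]c(=O)/c1=C\c1ccccc1OC` gives 2600 nM, compound 2 `C=CCn1c(=O)/c(=C\c2ccc(F)c(Br)c2)[nH]c(=O)/c1=C\c1ccccc1OC` gives "not active" (no number reported), and compound 3 `C=CCn1c(=O)/c(=C\c2ccccc2F)[nH]c(=O)/c1=C\c1ccccc1OC` gives 18500 nM. Among the two numbers shown, compound 3 stands highest; the single step that reaches it, a 7.1-fold higher number from compound 1 to compound 3 (0.85 log units; beyond the scatter), is the only measured step in the set.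

Compound 4 `C=CCn1c(=O)/c(=C\c2ccccc2Cl)[nH]c(=O)/c1=C\c1ccccc1OC` is the next entry. It differs from compound 3 as follows: chloro in place of fluoro on an aromatic carbon.

Going by the values given here, no measured step exchanges one halogen for another on that ring; the step from compound 1 to compound 3 replaces the whole 5-fluoro-2-methylphenyl by 2-fluorophenyl, so it does not bear directly on a chloro for fluoro swap. Compound 2 offers no number. With nothing to anchor a direction, the expectation for the step from compound 3 to compound 4 in this assay is a 1.2-fold lower number from compound 3 to compound 4 (0.09 log units; within the scatter), that is, no change beyond the scatter is expected, in either direction.

Compound 4 is therefore estimated at 15000 nM in this assay, with an expected range from 5000 nM to 45000 nM, and a fair chance that, as for compound 2, only a limit is reported.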

Compound 4, half-maximal inhibitory concentration: 4200 nM
The estimate for compound 4 lay 3.6-fold (0.55 log units) above the measured number; the measured number lies below the stated range.
By their numbers in this assay, from the lowest: compounds 1 and 4 (each within the scatter of the next); then compound 3.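

In this assay, going by these compounds alone, the halogen on this aromatic carbon, ortho to a large group, is not interchangeable: changing fluoro to chloro gives a 4.4-fold lower number from compound 3 to compound 4 (0.64 log units; beyond the scatter), the first reading of a single-atom change. The 2-chlorophenyl group also sits level with the 5-fluoro-2-methylphenyl group, at a 1.6-fold higher number from compound 1 to compound 4 (0.21 log units; within the scatter), so among these compounds the high number of compound 3 belongs to 2-fluorophenyl and not to every ring carrying one substituent in that place. The data offer no measured basis for explaining the gap between fluoro and chloro here.

Steps involving compound 2 cannot be read, as it has no number, so these results say nothing about how its bromo-bearing ring compares. Open questions are whether bromo, methyl, methoxy or an amine in the place of the chloro of compound 4 would extend the trend from fluoro to chloro or break it, and whether the chloro for fluoro gain holds in other assays or with a longer chain in place of the allyl group on the shared core.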